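This account rests on a few compounds, and the source may have more. Where it says the series, first, only, none or still open, it means among the compounds named here.

Measured in an ADME assay on MDCK cells (Canis lupus familiaris) for cytotoxicity, read by MTT assay, with a stated time of 24 h; a higher number here means that more compound is tolerated, a lower number that less compound is tolerated:
- compound 1 `N#CCCN(Cc1cccs1)S(=O)(=O)c1ccc(Br)cc1`: > 173000 nM
- compound 2 `COc1ccc(S(=O)(=O)N(CCC#N)Cc2cccs2)cc1`: > 198000 nM
- compound 3 `N#CCCN(Cc1cccs1)S(=O)(=O)c1ccc(C#N)cc1`: > 201000 nM

Each of these entries is a limit and not a number, so no order can be read among the three compounds. The next change leads to compound 4 `N#CCCN(Cc1ccco1)S(=O)(=O)c1ccc(C#N)cc1`, with furan-2-yl in place of thiophen-2-yl on a saturated chain carbon bound to a sulfonamide nitrogen.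

The measured steps are a step that the two limits leave unreadable from compound 1 to compound 2, a step that the two limits leave unreadable from compound 1 to compound 3 and a step that the two limits leave unreadable from compound 2 to compound 3. All three replace a group on an aromatic carbon, so none of them tests this change directly, and none has a readable size.

The expectation therefore rests on compound 3, whose limit is > 201000 nM. No step beyond the usual scatter is expected in this assay, and the estimated step that the limit leaves unreadable from compound 3 to compound 4 has no direction that can be relied on. Compound 4 is expected to be reported as a limit again. For compound 4 the estimated value is 210000 nM, with an expected range from 150000 nM to 300000 nM.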

Compound 4, half-maximal cytotoxic concentration: > 211000 nM
Compound 4: no number, only a limit; the forecaster's own chance of this, stated with the estimate: 85%; middle value at least 1.0-fold (0.00 log units) away from the limit.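

Compound 3 and compound 4 are both reported only as limits in this assay, and the exchange of thiophen-2-yl for furan-2-yl gives no readable step. The compounds shown leave open what concentration of any of them is actually half-maximally cytotoxic, and whether the two rings differ at all.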